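The source may report more compounds than this note shows. Statements on the series, on what has been measured and on what is new or still open speak of the compounds shown alone.

Compound 1 `CCc1ccc(NC(=O)c2cccc(/C=C3\CC(=O)N(c4ccccc4)C3=O)c2)cc1`: > 100000 nM
Compound 2 `CCc1cccc(NC(=O)c2cccc(/C=C3\CC(=O)N(c4ccccc4)C3=O)c2)c1`: 81200 nM
Compound 3 `O=C(Nc1ccc(F)cc1)c1cccc(/C=C2\CC(=O)N(c3ccccc3)C2=O)c1`: > 100000 nM

Among the compounds with values here, in an ADME assay on HCT-116 cells (Homo sapiens) for cytotoxicity, read by MTT assay, with a stated time of 72 h (on this read-out higher numbers stand for weaker inhibition and lower numbers for stronger inhibition), compound 2 gives 81200 nM, the only number among the three. Compound 1 gives only a limit, > 100000 nM. Compound 3 likewise gives only a limit, > 100000 nM. Compound 4 `CCc1cccc(NC(=O)c2cccc(/C=C3\CC(=O)N(c4ccc(C)cc4)C3=O)c2)c1` differs from compound 2 by methyl in place of hydrogen on an aromatic carbon. Within the data shown here, no measured step touches that part of the shared core; the measured steps change the amide-side ring, an at least 1.2-fold lower number from compound 1 to compound 2 (0.09 log units; that floor lies within the scatter) and an at least 1.2-fold higher number from compound 2 to compound 3 (0.09 log units; that floor lies within the scatter), and both are held at the floor by the limit of > 100000 nM in this assay, at which 2 of the 3 values shown sit. Among the measured compounds shown here, they offer no precedent, so no step beyond the scatter is expected: a 1.0-fold lower number from compound 2 to compound 4 (0.01 log units; within the scatter). Compound 4 is therefore estimated at 80000 nM, within 30000 nM to 200000 nM, with a real chance that only a limit is reported.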

Compound 4, half-maximal inhibitory concentration: 41500 nM
For compound 4 the middle estimate is 1.9-fold (0.29 log units) above the measured one; measured number inside the range.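

Phenyl to 4-methylphenyl is the first change shown on this ring of the shared core, and in this assay it gives a 2.0-fold lower number from compound 2 to compound 4 (0.29 log units; within the scatter). This position therefore carries a methyl with no step beyond the scatter, and compound 4 still gives a number rather than a limit. The earlier steps on the amide-side ring give no size to compare with this one, as they are held at a floor: the limit of > 100000 nM in this assay, at which 2 of the 4 values shown sit.

As far as these compounds go, what an amine, a carboxylic acid or a longer chain at this position would do remains open. So does whether a methyl here would read the same with another amide-side ring.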